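The source may hold more compounds than are shown below. What is called first, only, known or untested is meant among the compounds shown, and "the series" means these compounds.

Working notes on the series. The shared core carries a seven-heavy-atom group on the ring nitrogen and a halogen on the five-membered ring. Compound 1 `Nc1ncnc2c1c(Br)cn2COC(CO)CO` and compound 2 `Nc1ncnc2c1c(Cl)cn2COC(CO)CO` differ by bromo in place of chloro on an aromatic carbon; in a functional assay on L1210 cells (Mus musculus) for inhibition (a lower number here means a stronger inhibitor, a higher number a weaker inhibitor), compound 1 gives 710 nM, and compound 2 gives 2300 nM, so the step of a 3.2-fold lower number from compound 2 to compound 1 (0.51 log units; beyond the scatter) is modest but real. Compound 3 `OCC(CO)OCn1cc(Cl)c2c(NO)ncnc21` differs from compound 2 by hydroxy in place of hydrogen on a nitrogen on an aromatic ring, and in this assay compound 3 gives 75000 nM, a large step of a 33-fold higher number from compound 2 to compound 3 (1.51 log units; beyond the scatter). Compound 4 `OCC(CO)OCn1cc(Br)c2c(NO)ncnc21`, not yet measured, differs from compound 3 by bromo in place of chloro on an aromatic carbon, the same change as from compound 2 to compound 1. Resting on a 3.2-fold lower number from compound 2 to compound 1 (0.51 log units; beyond the scatter), a step of similar size is expected, a 3.0-fold lower number from compound 3 to compound 4 (0.48 log units; beyond the scatter). Compound 4 is therefore estimated at 25000 nM in this assay, plausibly between 8000 nM and 70000 nM.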

Compound 4, half-maximal inhibitory concentration: 3700 nM
The estimate for compound 4 lay 6.8-fold (0.83 log units) above the measured number, outside the stated range (below it).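

Bromo in place of chloro on an aromatic carbon lowers the number on both cores in this assay, but the size of the step does not carry from one core to the other, with a 20-fold lower number from compound 3 to compound 4 (1.31 log units; beyond the scatter) on the hydroxy-bearing core: the same change on two cores in this assay, a 3.2-fold lower number (0.51 log units; beyond the scatter) from compound 2 to compound 1 and a 20-fold lower number (1.31 log units; beyond the scatter) from compound 3 to compound 4, 6.3-fold (0.80 log units) apart, beyond the scatter of two such steps. Read the other way, hydroxy in place of hydrogen on a nitrogen raises the number with either halogen, and with bromo the result is a 5.2-fold higher number from compound 1 to compound 4 (0.72 log units; beyond the scatter): the same change on two cores in this assay, a 33-fold higher number (1.51 log units; beyond the scatter) from compound 2 to compound 3 and a 5.2-fold higher number (0.72 log units; beyond the scatter) from compound 1 to compound 4, 6.3-fold (0.80 log units) apart, beyond the scatter of two such steps. These four compounds show that the two changes are not independent here and that only the direction carried over; they give no cause and no rule for any other core.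

Going by these compounds, whether iodo on the same aromatic carbon would extend the bromo result remains open. So does whether methoxy in place of hydroxy on that nitrogen would show the same dependence on the halogen.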